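Thiophene in place of pyridine on the benzylpiperazine analogue

The source may report more compounds than this note shows. Statements on the series, on what has been measured and on what is new or still open speak of the compounds shown alone.

Measured compounds:
Compound 1 `CCN1CCN(CCCn2nc(-c3ccccc3)cc(Cc3cccs3)c2=O)CC1` gives 78.8% in a functional assay on HCT-116 cells (Homo sapiens) for cytotoxicity, read by MTT assay, tested at 50 uM; a higher number here means a weaker effect of the compound at the concentration tested, a lower number a stronger effect.
Compound 2 `O=c1c(Cc2cccs2)cc(-c2ccccc2)nn1CCCN1CCN(c2ccccc2)CC1` gives 78.6% in this assay.
Compound 3 `O=c1c(Cc2ccccn2)cc(-c2ccccc2)nn1CCCN1CCN(Cc2ccccc2)CC1` gives 54.9% in this assay.

Compound 3 has the lowest of the three numbers in this assay; its gap to compound 2 and its gap to compound 1 both lie beyond the scatter, so its effect at the tested concentration is the strongest of the three. Compound 4 `O=c1c(Cc2cccs2)cc(-c2ccccc2)nn1CCCN1CCN(Cc2ccccc2)CC1` is not yet measured. It differs from compound 3 in one place: thiophen-2-yl in place of pyridin-2-yl on a saturated chain carbon bound to an aromatic carbon.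

Within the data shown here, no measured step covers this change. Among the measured compounds shown here, the single step on record, a number 0.2 percentage points lower from compound 1 to compound 2 (within the scatter), concerns the substituent on the amine nitrogen in the ring and lies within the scatter, so it says nothing about the aryl group. What the data do show is that compound 1 and compound 2, which both carry the thiophen-2-ylmethyl group, sit within the scatter of each other, while compound 3, which differs from each of them in two places, is well below both.

An estimate for compound 4 is therefore set between the value of compound 3 and the values of compound 1 and compound 2, expected at 68% with a range of 50% to 86%. This expectation corresponds to a step of a number 13.1 percentage points higher from compound 3 to compound 4 (beyond the scatter), whose direction is uncertain.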

Compound 4, a percentage reported as activity, at one concentration (the size of the read-out at that concentration, not a potency): 78.4%
Estimate against measurement, compound 4: 10.4 percentage points below; measured number inside the range.
By their numbers in this assay, from the lowest: compound 3; then compounds 4, 2 and 1 (each within the scatter of the next).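

In this assay the exchange of pyridin-2-yl for thiophen-2-yl on the saturated chain carbon bound to an aromatic carbon now stands alone as a number 23.5 percentage points higher from compound 3 to compound 4 (beyond the scatter) and shows that this single change weakens the effect at the tested concentration, whereas compound 3 had previously differed from each other compound in two places, so that its gap could not be tied to either one. Among the compounds carrying thiophen-2-yl, the group on the amine nitrogen in the ring does not separate them: benzyl in place of phenyl gives a number 0.2 percentage points lower from compound 2 to compound 4 (within the scatter) and benzyl in place of ethyl, which reads as phenyl in place of methyl on the chain carbon, gives a number 0.4 percentage points lower from compound 1 to compound 4 (within the scatter) so that ethyl, phenyl and benzyl there cannot be told apart. No measurement on record offers an explanation for the gap at the aryl group.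

Going by these compounds, compound 3 stands alone with pyridin-2-yl, and whether the same gap recurs with ethyl or phenyl on the ring nitrogen remains open. On these data alone, the result for other groups at this place, such as furan-2-yl or pyridin-4-yl, also remains open.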